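The source may hold more compounds than are shown below. What is called first, only, known or untested is meant among the compounds shown, and "the series" means these compounds.

Compound 1: `COc1ccc(S(=O)(=O)c2cnc3cc(Cl)ccc3c2N2CCC(C)CC2)cc1Cl` — 93%
Compound 2: `Cc1ccc2ncc(S(=O)(=O)c3ccc(C)c(Cl)c3)c(N3CCC(C)CC3)c2c1` — 91%

Of the compounds shown here, two have been tested in an assay on isolated protein for displacement of a labelled ligand from metabotropic glutamate receptor 5 (Homo sapiens), with a stated time of 60 min, tested at 1 uM; on this read-out lower numbers stand for less inhibition and higher numbers for more inhibition at the one concentration tested (going by the name of the read-out). Compound 1 and compound 2 lie within the scatter of each other, so neither number stands apart from the other. Compound 3, `COc1ccc(S(=O)(=O)c2cnc3cc(Cl)ccc3c2N2CCC(C)CC2)cc1`, has not yet been measured. It differs from compound 1 in one place: hydrogen in place of chloro on an aromatic carbon. Within the data shown here, no measured pair shows what this change does, so the expectation rests on compound 1 alone. The step of a number 8 percentage points lower from compound 1 to compound 3 (within the scatter) is expected to be small and downward, not clearly beyond the scatter. Compound 3 is therefore estimated at 85%, with a likely range from 60% to 97%.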

Compound 3, a percentage reported as inhibition, at one concentration (the size of the read-out at that concentration, not a potency): 79%
Compound 3: middle estimate off by 6 percentage points, on the high side; low and high end bracket the measured number.
By their numbers in this assay, from the lowest: compound 3; then compounds 2 and 1 (each within the scatter of the next).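

In this assay, the chloro ortho to the methoxy group proves to matter to this read-out: going from 3-chloro-4-methoxyphenyl to 4-methoxyphenyl gives a number 14 percentage points lower from compound 1 to compound 3 (beyond the scatter). Without the chloro, compound 3 still reads 79%, so this inhibition at the one concentration tested does not depend on that group. No available measurement explains the step.

On these data alone, whether fluoro, bromo or methyl on the same aromatic carbon would match chloro remains open. So does whether this step would hold with the other groups on the core of compound 1 changed.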